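Removing the methyl group from compound 3

This account rests on a few compounds, and the source may have more. Where it says the series, first, only, none or still open, it means among the compounds named here.

Compound 1 (`C/C(=C\CC/C(C)=C/CC[C@@H]1[C@@]2(C)CCC(=O)C(C)(C)[C@H]2CC[C@@]1(C)O)CC/C=C(\C)C(=O)OCc1cn(-c2ccc(F)cc2)nn1`), compound 2 (`COc1ccccc1-n1cc(COC(=O)/C(C)=C/CC/C(C)=C/CC/C(C)=C/CC[C@@H]2[C@@]3(C)CCC(=O)C(C)(C)[C@H]3CC[C@@]2(C)O)nn1`) and compound 3 (`C/C(=C\CC/C(C)=C/CC[C@@H]1[C@@]2(C)CCC(=O)C(C)(C)[C@H]2CC[C@@]1(C)O)CC/C=C(\C)C(=O)OCc1cn(-c2ccccc2C)nn1`) were tested in a functional assay on DU-145 cells (Homo sapiens) for antiproliferative activity, read by MTT assay, with a stated time of 48 h; on this read-out lower numbers stand for stronger inhibition and higher numbers for weaker inhibition. Compound 1 gives > 150000 nM, which is a limit. Compound 2 gives > 150000 nM, also a limit. Compound 3 gives > 150000 nM, again a limit. Compound 3 thus stands with the others at the limit of > 150000 nM in this assay, at which 3 of the 3 values shown sit. Compound 4 (`C/C(=C\CC/C(C)=C/CC[C@@H]1[C@@]2(C)CCC(=O)C(C)(C)[C@H]2CC[C@@]1(C)O)CC/C=C(\C)C(=O)OCc1cn(-c2ccccc2)nn1`) differs from compound 3 as hydrogen in place of methyl on an aromatic carbon. The measured steps that bear on it are a step that the two limits leave unreadable from compound 1 to compound 2, a step that the two limits leave unreadable from compound 1 to compound 3 and a step that the two limits leave unreadable from compound 2 to compound 3, so none has a readable size. No change beyond the scatter is expected, and the expected step is a step that the limit leaves unreadable from compound 3 to compound 4. For compound 4 the estimate is 170000 nM, with an expected range from 70000 nM to 340000 nM.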

Compound 4, half-maximal inhibitory concentration: 95500 nM
The estimate for compound 4 lay 1.8-fold (0.25 log units) above the measured number; the range from low to high includes it.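

Within the data shown here, compound 4, with hydrogen on the aromatic carbon ortho to a large group, is the first compound here to give a number rather than a limit in this assay. Hydrogen in place of methyl gives an at least 1.5-fold lower number from compound 3 to compound 4 (0.19 log units; that floor lies within the scatter), hydrogen in place of methoxy gives an at least 1.5-fold lower number from compound 2 to compound 4 (0.19 log units; that floor lies within the scatter), and hydrogen in place of fluoro gives an at least 1.5-fold lower number from compound 1 to compound 4 (0.19 log units; that floor lies within the scatter). The three substituted compounds give only a limit, so the true size of each step stays unknown: the limit of > 150000 nM in this assay, at which 3 of the 4 values shown sit.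

The compounds shown leave open whether an amine or a carboxylic acid on this phenyl ring would give a number rather than a limit.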